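Cytotoxicity notes on the series, compound 3 toward compound 4

The source may hold more compounds than are shown below. What is called first, only, known or untested is meant among the compounds shown, and "the series" means these compounds.

Measured so far in an ADME assay on HepG2 2.2.15 cells (Homo sapiens) for cytotoxicity; a higher number here means that more compound is tolerated, a lower number that less compound is tolerated:
- compound 1 `CC(C)(C)OC(=O)Nc1ncc(C(Oc2ccc(Br)cc2)c2ccc(Cl)cc2)s1`: > 50000 nM, a limit of the assay, not a number
- compound 2 `CC(C)(C)OC(=O)Nc1ncc(C(Oc2ccc(F)c(Cl)c2)c2ccc(Cl)cc2)s1`: > 50000 nM, a limit of the assay, not a number
- compound 3 `O=C(Nc1ncc(C(Oc2ccc3cc(Br)ccc3c2)c2ccc(Cl)cc2)s1)c1cccs1`: "not toxic" (no number reported), reported without a number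

Compound 3 thus stands outside the numbers: its read-out is a verbal report only, and the two further values in this assay are both limits, so no ranking of compound 3 against compound 1 or compound 2 can be read. Among the compounds with values here, the one measured step, a step that the two limits leave unreadable from compound 1 to compound 2, sits between two limits and its size is unreadable; it also concerns a different place than the change now followed, and the reading at the limit of > 50000 nM in this assay, at which 2 of the 3 values shown sit, is all the series offers.

Compound 4 `COC(=O)CCCCNc1ncc(C(Oc2ccc3cc(Br)ccc3c2)c2ccc(Cl)cc2)s1` differs from compound 3 by 4-(methoxycarbonyl)butyl in place of (thiophen-2-yl)carbonyl on a nitrogen on an aromatic ring. Within the data shown here, no measured step bears on this change, and the available values give no direction for this assay beyond the limit.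

For compound 4 a value at the limit is expected, estimated at 50000 nM in this assay, with a range from 20000 nM to 100000 nM.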

Compound 4, half-maximal cytotoxic concentration: "not toxic" (no number reported)
The entry for compound 4 holds no number, and the estimate cannot be compared.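

Compound 3 and compound 4 are both reported in this assay as not toxic, without a number, and no step can be read from one to the other. The compounds shown leave open whether 4-(methoxycarbonyl)butyl in place of (thiophen-2-yl)carbonyl shifts tolerance at all, as the only numerical reading remains a limit: the limit of > 50000 nM in this assay, at which 2 of the 4 values shown sit.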